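Thiosemicarbazone series: aryl chloro step toward compound 4

The source may report more compounds than this note shows. Statements on the series, on what has been measured and on what is new or still open speak of the compounds shown alone.

Measured so far in a functional assay on MOLT-4 cells (Homo sapiens), with a stated time of 72 h; on this read-out lower numbers stand for stronger inhibition and higher numbers for weaker inhibition:
- compound 1 `O=C1/C(=N\NC(=S)Nc2ccc(Cl)cc2)c2cc(Cl)ccc2N1Cc1ccc(Cl)cc1`: 58000 nM
- compound 2 `O=C1/C(=N\NC(=S)Nc2ccc(Cl)cc2)c2cc(Br)ccc2N1Cc1ccc(F)cc1`: 48000 nM
- compound 3 `Cc1ccc(NC(=S)N/N=C2\C(=O)N(Cc3ccc(Cl)cc3)c3ccc(Br)cc32)cc1`: 288000 nM

Compound 3 stands highest of the three numbers. Compound 1 with 58000 nM and compound 2 with 48000 nM both lie well below it, each gap beyond the usual scatter, and both of these carry the 4-chlorophenyl thiourea end, whereas compound 3 carries the 4-methylphenyl end.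

Compound 4 `O=C1/C(=N\NC(=S)Nc2ccc(Cl)cc2)c2cc(Br)ccc2N1Cc1ccc(Cl)cc1` has not yet been measured in this assay. It differs from compound 3 by chloro in place of methyl on an aromatic carbon, so that compound 4 shares the 4-chlorophenyl thiourea end with compound 1 and compound 2 while keeping the bromo-bearing core and the 4-chlorobenzyl group of compound 3. For the measured compounds named here, no step between measured compounds isolates this single change. Given the numbers of compound 1 and compound 2, compound 4 is expected to move downward in this assay by a step beyond the scatter, toward their range. The expected step is a 5.2-fold lower number from compound 3 to compound 4 (0.72 log units; beyond the scatter). Compound 4 is accordingly estimated at 55000 nM, with a range of 25000 nM to 120000 nM.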

Compound 4, half-maximal inhibitory concentration: 280000 nM
Compound 4: the middle estimate sits 5.1-fold (0.71 log units) below what was measured; the whole stated range lies below it.
By their numbers in this assay, from the lowest: compounds 2 and 1 (each within the scatter of the next); then compounds 4 and 3 (each within the scatter of the next).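

In this assay, chloro in place of methyl on the aromatic ring of the thiourea end gives a 1.0-fold lower number from compound 3 to compound 4 (0.01 log units; within the scatter), so the two groups are not told apart at this position on this background. The steps beyond the scatter lie at the other two places: chloro in place of fluoro on the benzyl group gives a 5.8-fold higher number from compound 2 to compound 4 (0.77 log units; beyond the scatter), and bromo in place of chloro on the core gives a 4.8-fold higher number from compound 1 to compound 4 (0.68 log units; beyond the scatter). No measured evidence bearing on the reason for these steps is available.

From the compounds shown here alone, each of these steps rests on a single pair, so whether it holds on other backgrounds remains open. Going by these compounds, how a methoxy group, an amine or a carboxylic acid would compare with methyl and chloro at this position also remains open.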